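Methyl in place of bromo on the aromatic ring of compound 3

The source may report more compounds than this note shows. Statements on the series, on what has been measured and on what is new or still open speak of the compounds shown alone.

Compound 3 `C=C[C@@H]1OC(c2ccc(Br)cc2)=N[C@H]1CO` gives the lower of the two numbers measured in an assay on isolated protein for inhibition of matrix metalloproteinase-9 (Homo sapiens) (on this read-out lower numbers stand for stronger inhibition and higher numbers for weaker inhibition), at 9000 nM. Compound 1 `C=C[C@@H]1OC(c2ccc(-c3ccccc3)cc2)=N[C@H]1CO` gives 24000 nM. Compound 2 `C=C[C@@H]1OC(c2ccccc2)=N[C@H]1CO` reaches only a limit of the assay, > 4000000 nM, in line with the limit of > 4000000 nM in this assay, at which 1 of the 3 values shown sits. Compound 4 `C=C[C@@H]1OC(c2ccc(C)cc2)=N[C@H]1CO` differs from compound 3 by methyl in place of bromo on an aromatic carbon. Among the compounds with values here, two measured steps bear on this change: an at least 440-fold lower number from compound 2 to compound 3 (2.64 log units; beyond the scatter), and a 2.7-fold lower number from compound 1 to compound 3 (0.43 log units; beyond the scatter). Methyl, like bromo, keeps a substituent on that aromatic carbon, so the large step seen with no substituent is not expected to recur; a modest rise in the number in this assay, a 2.8-fold higher number from compound 3 to compound 4 (0.44 log units; beyond the scatter), is the expectation. Compound 4 is therefore estimated at 25000 nM, with a range of 8000 nM to 90000 nM.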

Compound 4, inhibition constant: 68000 nM
Beside the measured number, compound 4's estimate is 2.7-fold (0.43 log units) below it, within the range that was stated.
By their numbers in this assay, from the lowest: compound 3; then compound 1; then compound 4. At a limit, above all of these: compound 2.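

In this assay, methyl also keeps the number far from that of the unsubstituted compound (an at least 58-fold lower number from compound 2 to compound 4 (1.76 log units; beyond the scatter)), though this step starts from a limit of the assay, so the gain is not unique to bromo. The substituents are still not interchangeable: methyl falls behind bromo (a 7.6-fold higher number from compound 3 to compound 4 (0.88 log units; beyond the scatter)) even though one heavy atom replaces one heavy atom. It also falls behind phenyl (a 2.8-fold higher number from compound 1 to compound 4 (0.45 log units; beyond the scatter)), so the order here is bromo, then phenyl, then methyl.

On these data alone, how an amine, a carboxylic acid or a longer chain on this aromatic carbon would compare remains open. So does whether this order holds at other positions on the shared core.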